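The source may report more compounds than this note shows. Statements on the series, on what has been measured and on what is new or still open speak of the compounds shown alone.

The series shares one core. Compound 1 `Cn1c(=O)c2nc(-c3cccc(F)c3)[nH]c2n(C)c1=O` gives 4 nM in an assay for binding affinity to adenosine receptor A1 (Bos taurus); on this read-out higher numbers stand for weaker inhibition and lower numbers for stronger inhibition. Compound 2 `CCCCOc1ccc(-c2nc3c(=O)n(C)c(=O)n(C)c3[nH]2)cc1` gives 4 nM in this assay, level with compound 1 at the digits shown; together these two are the highest of the three numbers, and the gap between them lies within the scatter. Compound 3 `CCn1c(=O)c2nc(-c3ccc(S(=O)(=O)NCCN(C)C)cc3)[nH]c2n(CC)c1=O` gives 3.3 nM, and the gap from compound 2 to compound 3 also lies within the scatter. Compound 4 `CCOc1ccc(-c2nc3c(=O)n(C)c(=O)n(C)c3[nH]2)cc1` has not been measured in this assay. It differs from compound 2 in one place: hydrogen in place of ethyl on a saturated chain carbon, two bonds along the chain from an oxygen on an aromatic ring. Among the measured compounds shown here, no measured pair shows this change, so the direction rests on the structures alone. In this assay the expected step is modest, toward a higher number: a 2.5-fold higher number from compound 2 to compound 4 (0.40 log units; beyond the scatter). Compound 4 is estimated at 10 nM, between 4 nM and 30 nM.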

Compound 4, half-maximal inhibitory concentration: 2 nM
For compound 4 the middle estimate is 5.0-fold (0.70 log units) above the measured one; the measured number lies below the stated range.
By their numbers in this assay, from the lowest: compounds 4, 3, 1 and 2 (each within the scatter of the next).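

Butoxy to ethoxy gives a 2.0-fold lower number from compound 2 to compound 4 (0.30 log units; within the scatter) in this assay. Among the compounds shown here, this first measured pair at this position shows that removing ethyl from the chain, two bonds along from the oxygen on the aromatic ring, produces no step that can be told apart from repeat measurements. Nothing shown gives a reason for this result. The compounds shown leave open how a methoxy group, a longer chain than butoxy, or an amine or carboxylic acid at the chain end would read here. They also leave open whether this holds with the ethyl groups on the core of compound 3.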